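Three Cytotoxicity Limits and an Expected Fourth

This account rests on a few compounds, and the source may have more. Where it says the series, first, only, none or still open, it means among the compounds named here.

Compound 1, `CC(C)N(Cc1cccc(OCCCCCC(=O)O)c1)C(=O)c1ccc(-c2cccc3ccccc23)cc1`, gives > 26000 nM in an ADME assay on HEK293 cells (Homo sapiens) for cytotoxicity, read by CellTiter-Glo and resazurin assay, with a stated time of 72 h; on this read-out higher numbers stand for an effect only at larger amounts of compound and lower numbers for an effect already at smaller amounts; this value is a limit of the assay.
Compound 2, `CC(C)N(Cc1cccc(OCCCCCC(=O)O)c1)C(=O)c1ccc(-c2cccc(-c3ccccc3)c2)cc1`, gives > 26000 nM in this assay; this value is a limit of the assay.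
Compound 3, `Cc1nnc(-c2cccc(-c3ccc(C(=O)N(Cc4cccc(OCCCCCC(=O)O)c4)C(C)C)cc3)c2)o1`, gives > 26000 nM in this assay; this value is a limit of the assay.

All three measured compounds sit at the same limit, as the evidence shows: the limit of > 26000 nM in this assay, at which 3 of the 3 values shown sit. Compound 3 therefore stands at that limit, and its two companions stand at it as well, so no order among the three can be read.

The measured steps give no size. From compound 1 to compound 2 the step is a step that the two limits leave unreadable from compound 1 to compound 2. From compound 1 to compound 3 the step is a step that the two limits leave unreadable from compound 1 to compound 3. From compound 2 to compound 3 the step is a step that the two limits leave unreadable from compound 2 to compound 3.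

Compound 4, `COc1cc(F)cc(-c2ccc(C(=O)N(Cc3cccc(OCCCCCC(=O)O)c3)C(C)C)cc2)c1`, is not yet measured. It differs from compound 3 as follows: 3-fluoro-5-methoxyphenyl in place of 3-(5-methyl-1,3,4-oxadiazol-2-yl)phenyl on an aromatic carbon.

All three steps among the measured compounds bear on this change only in that none of them produced a readable number, so no direction or size can be drawn from them. Compound 4 is therefore expected to sit at the limit again, with an expected step that the limit leaves unreadable from compound 3 to compound 4 from compound 3 to compound 4. The estimate for compound 4 in this assay is 40000 nM, with an expected range from 20000 nM to 100000 nM.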

Compound 4, half-maximal effective concentration: > 26000 nM
Compound 4: only a limit was reported; the forecaster's own chance of this, stated with the estimate: 85%; the middle value lies beyond the limit too.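

Compound 4 shows only a limit, so no step from compound 1, compound 2 or compound 3 to compound 4 can be read in this assay, and all four compounds share one limit: the limit of > 26000 nM in this assay, at which 4 of the 4 values shown sit.

The compounds shown leave open at what concentration any of the four would show an effect in this assay, and whether the groups exchanged on the shared core make any difference there.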